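Sulfonyl aryl variation on a shared amide core

The source may hold more compounds than are shown below. What is called first, only, known or untested is meant among the compounds shown, and "the series" means these compounds.

Compound 1 `Cc1ccccc1S(=O)(=O)c1ccc(CNC(=O)c2cc3cnccc3[nH]2)cc1` gives 13 nM in a functional assay on A2780 cells (Homo sapiens) for inhibition, read by sulforhodamine B assay, with a stated time of 72 h; a lower number here means a stronger inhibitor, a higher number a weaker inhibitor; compound 2 `O=C(NCc1ccc(S(=O)(=O)c2cccc(F)c2)cc1)c1cc2cnccc2[nH]1` gives 11 nM.

Compound 2 stands at the lowest of the two numbers in this assay, though its nearest neighbour is compound 1, and the step of a 1.2-fold lower number from compound 1 to compound 2 (0.07 log units; within the scatter) lies within the scatter, so the two compounds cannot be ordered. Compound 3 `O=C(NCc1ccc(S(=O)(=O)c2ccccc2C(F)(F)F)cc1)c1cc2cnccc2[nH]1` has not yet been measured. It differs from compound 2 in one place: 2-(trifluoromethyl)phenyl in place of 3-fluorophenyl on a sulfonyl sulfur. Among the compounds with values here, the only measured step that bears on this change is the one from compound 1 to compound 2, which also swapped the aryl group on the sulfonyl sulfur and produced no movement beyond the scatter, a 1.2-fold lower number from compound 1 to compound 2 (0.07 log units; within the scatter). Within the data shown here, with a single step of that size as the only guide, compound 3 is expected to sit close to compound 2, with a step of a 1.2-fold higher number from compound 2 to compound 3 (0.07 log units; within the scatter) estimated to fall within the scatter. The estimate for compound 3 in this assay is therefore 13 nM, with a range from 5 nM to 35 nM, the width reflecting that no trifluoromethyl-bearing group has been measured here.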

Compound 3, half-maximal inhibitory concentration: 25 nM
Beside the measured number, compound 3's estimate is 1.9-fold (0.28 log units) below it; the range from low to high includes it.
By their numbers in this assay, from the lowest: compounds 2, 1 and 3 (each within the scatter of the next, the first and the last beyond it).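

In this assay, the aryl group on the sulfonyl sulfur, whose other neighbour is an aromatic carbon, can shift the number beyond the scatter, as the 2-(trifluoromethyl)phenyl for 3-fluorophenyl change shows (a 2.3-fold higher number from compound 2 to compound 3 (0.36 log units; beyond the scatter)), although that shift is modest. This differs from the earlier aryl swap, which stayed within the scatter (a 1.2-fold lower number from compound 1 to compound 2 (0.07 log units; within the scatter)), so the position is not wholly indifferent to which aryl group it carries. Trifluoromethyl in place of methyl on an aromatic carbon gives a step that remains within the scatter (a 1.9-fold higher number from compound 1 to compound 3 (0.28 log units; within the scatter)), so compound 1 and compound 3 cannot be ordered, and only the pair of compound 2 and compound 3 separates. Nothing available here explains the step between compound 2 and compound 3.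

The compounds shown leave open whether the position would tolerate a carboxylic acid or an amine on the aryl ring, or a plain phenyl group with no added substituent. They also leave open whether the modest step seen here would hold with a longer alkyl chain, such as ethyl, in place of methyl or trifluoromethyl.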